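Working notes: from compound 2 to compound 3

The compounds below may be only part of what the source reports. "The series", "measured", "known", "first", "only" and "open" are said of these compounds alone.

Measured so far in a functional assay on HepG2 cells (Homo sapiens) for antiproliferative activity, read by MTT assay, with a stated time of 48 h; on this read-out higher numbers stand for weaker inhibition and lower numbers for stronger inhibition
- Compound 1 `COc1ccc(-c2c(Nc3ccc(C)c(O)c3)c3ccccc3oc2=O)cc1` gives 10200 nM
- Compound 2 `COc1ccc(-c2c(Nc3ccc(F)cc3)c3ccc(O)cc3oc2=O)cc1` gives 65600 nM

Of these two numbers, the higher belongs to compound 2 (65600 nM), which makes it the weaker inhibitor of the pair, and its gap to compound 1 lies beyond the scatter. Going by the values given here, the two measured compounds differ in more than one place, so no single-change step is available as a guide.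

Compound 3 `COc1ccc(-c2c(Nc3ccc(C)c(O)c3)c3ccc(O)cc3oc2=O)cc1` has not yet been measured in this assay. One change separates it from compound 2: 3-hydroxy-4-methylphenyl in place of 4-fluorophenyl on a nitrogen on an aromatic ring. The entering group is also present in compound 1 (10200 nM), the lower of the two numbers, so a moderate fall in the number is expected, towards stronger inhibition. Among the compounds with values here, with only two measured compounds behind this, the step may barely clear the scatter. The expected step is a 3.0-fold lower number from compound 2 to compound 3 (0.47 log units; beyond the scatter) in size. The estimate for compound 3 is 22000 nM (expected range 7000 nM to 65000 nM).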

Compound 3, half-maximal inhibitory concentration: > 75300 nM
Compound 3: no number, only a limit; the forecaster's own chance of this, stated with the estimate: 10%; at least 3.4-fold (0.53 log units) between middle value and limit.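

Compound 3 gives no number in this assay, only a limit of the assay: the limit of > 75300 nM in this assay, at which 1 of the 3 values shown sits.

Hydroxy in place of hydrogen on an aromatic carbon, with the 3-hydroxy-4-methylphenyl group held fixed, gives an at least 7.3-fold higher number from compound 1 to compound 3 (0.86 log units; beyond the scatter) and is the first single-change reading of that hydroxy, a clear loss of inhibition in this pair. Exchanging 4-fluorophenyl for 3-hydroxy-4-methylphenyl on a nitrogen on an aromatic ring gives an at least 1.1-fold higher number from compound 2 to compound 3 (0.05 log units; that floor lies within the scatter) and so shows no gain in inhibition on the core of compound 2, although the true size of this step stays hidden behind the limit. The stronger inhibition seen with compound 1 therefore does not carry over to the hydroxy-bearing core through the 3-hydroxy-4-methylphenyl group alone.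

Open, from the compounds shown here alone, is whether the loss belongs to the hydroxy itself or would also follow from another group at that aromatic carbon, such as an amine or a carboxylic acid. Also open, going by these compounds, is how 4-fluorophenyl on the nitrogen would read on the core of compound 1, and how far the number of compound 3 lies past the limit.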